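From fluoro to acetoxy on an aromatic carbon

A few compounds are considered here, and "the series" means these few. Any claim that something is new, unique, unknown or untested is made for them only; others in the source may bear on it.

Compound 1 `CC(=C\c1ccccc1)/C=C1\CCC=CC1=O` gives 4800 nM
Compound 2 `O=C1C=CCC/C1=C\C=C\c1ccc(F)cc1` gives 2200 nM
Compound 3 `COc1ccccc1/C=C/C=C1\CCC=CC1=O` gives 2800 nM

In a functional assay on HCT-116 cells (Homo sapiens) for cytotoxicity, read by MTT assay, with a stated time of 72 h (a lower number here means a stronger inhibitor, a higher number a weaker inhibitor), compound 2 gives 2200 nM and stands within the scatter of compound 3 (2800 nM), while lying lower, beyond the scatter, than compound 1 (4800 nM). Compound 4 `CC(=O)Oc1ccc(/C=C/C=C2\CCC=CC2=O)cc1` has acetoxy in place of fluoro on an aromatic carbon, para to a large group (acetoxy in place of fluoro on an aromatic carbon). For the measured compounds named here, no measured pair differs in just one place, so direct guidance is missing. Compound 3 (2800 nM) carries another group on its aromatic ring and stays within the scatter of compound 2, so in this assay a small move towards a higher number, perhaps none beyond the scatter, is expected. The expected step (a 1.4-fold higher number from compound 2 to compound 4 (0.13 log units; within the scatter)) is small. Compound 4 is expected to read about 3000 nM (estimated range 1200 nM to 7000 nM).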

Compound 4, half-maximal inhibitory concentration: 4600 nM
Compound 4: the middle estimate sits 1.5-fold (0.19 log units) below what was measured; the range from low to high includes it.
By their numbers in this assay, from the lowest: compounds 2, 3, 4 and 1 (each within the scatter of the next, the first and the last beyond it).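

In this assay, placing acetoxy instead of fluoro on this aromatic carbon, para to a large group, gives a 2.1-fold higher number from compound 2 to compound 4 (0.32 log units; beyond the scatter) as the first step read between compounds differing in one place. This shows that the position is sensitive to what it carries, though only modestly for a change from one heavy atom to four. Nothing available here explains the shift.

From the compounds shown here alone, whether a hydroxyl or an amine on the same carbon would give a similar number remains open. A single step also cannot show whether size or some other feature of the group matters.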